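The source may hold more compounds than are shown below. What is called first, only, known or untested is meant among the compounds shown, and "the series" means these compounds.

The shared core of compounds 1, 2 and 3 is carried through this small set, and the three differ only in the aromatic group attached to it. Compound 1 `Cc1nc2c3ccccc3ccc2c2nc3c(ccc4ccccc43)c(-c3cccc([N+](=O)[O-])c3)c12` bears a 3-nitrophenyl group; in a functional assay, read by spectrophotometry, with a stated time of 30 min (on this read-out lower numbers stand for stronger inhibition and higher numbers for weaker inhibition), compound 1 gives 117 ug/mL. Compound 2 `Cc1nc2c3ccccc3ccc2c2nc3c(ccc4ccccc43)c(-c3cccnc3)c12` bears a pyridin-3-yl group, and in this assay compound 2 gives 98.2 ug/mL. Compound 3 `Cc1nc2c3ccccc3ccc2c2nc3c(ccc4ccccc43)c(-c3cc(O)nc4ccccc34)c12` bears a 2-hydroxyquinolin-4-yl group, and in this assay compound 3 gives 92.1 ug/mL. Compound 2 stands close to both neighbours: the step of a 1.2-fold lower number from compound 1 to compound 2 (0.08 log units; within the scatter) and the step of a 1.1-fold lower number from compound 2 to compound 3 (0.03 log units; within the scatter) both fall inside the scatter, as does a 1.3-fold lower number from compound 1 to compound 3 (0.10 log units; within the scatter), so the three numbers cannot be told apart.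

The unmeasured compound 4 `Cc1nc2c3ccccc3ccc2c2nc3c(ccc4ccccc43)c(-c3ccccc3)c12` is reached from compound 2 by a single change: phenyl in place of pyridin-3-yl on an aromatic carbon. Every measured step in this set exchanges one aromatic group for another on the same carbon, and none moved the number beyond the scatter. On that basis the change from compound 2 to compound 4 is expected to give no step beyond the scatter in this assay, in either direction, as a 1.0-fold higher number from compound 2 to compound 4 (0.01 log units; within the scatter). For compound 4 the estimated value in this assay is 100 ug/mL, with a range from 60 ug/mL to 170 ug/mL.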

Compound 4, half-maximal inhibitory concentration: 164 ug/mL
Compound 4: the middle estimate sits 1.6-fold (0.21 log units) below what was measured; low and high end bracket the measured number.
By their numbers in this assay, from the lowest: compounds 3, 2, 1 and 4 (each within the scatter of the next).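

In this assay the step of a 1.7-fold higher number from compound 2 to compound 4 (0.22 log units; within the scatter) stays within the scatter, so the hydrogen-bond acceptor counted for pyridin-3-yl and absent from phenyl is not shown to matter on this aromatic carbon opposite the ring nitrogen. Phenyl also gives the set its unsubstituted carbon ring, and neither the step of a 1.4-fold higher number from compound 1 to compound 4 (0.15 log units; within the scatter), which takes away the nitro group, nor the step of a 1.8-fold higher number from compound 3 to compound 4 (0.25 log units; within the scatter), which replaces 2-hydroxyquinolin-4-yl, can be told apart from the scatter, so all four aromatic groups remain indistinguishable at this position in this read-out. No other measurement bears on these results.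

Every group shown on this carbon is an aromatic ring, so it remains open whether an amine, a carboxylic acid or a longer alkyl chain there would move the number beyond the scatter. The shared core is also the same throughout, which leaves open whether a change elsewhere on it would have a clearer effect than these exchanges of one aromatic group for another.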